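The source may report more compounds than this note shows. Statements on the series, on what has been measured and on what is new or still open speak of the compounds shown alone.

Compound 1 `N#CN/C(=N\CCOC(=O)c1ccccc1)NCCCOc1cccc(CN2CCCCC2)c1` gives 7.64 in a functional assay on cardiac atrium for antagonist activity at histamine H2 receptor (Cavia porcellus); on this read-out higher numbers stand for higher potency (the scale is a negative logarithm) and lower numbers for lower potency. Compound 2 `N#CN/C(=N\CCNc1ccc(N=[N+]=[N-])cc1[N+](=O)[O-])NCCCOc1cccc(CN2CCCCC2)c1` gives 7.39 in this assay. Compound 3 `N#CN/C(=N\CCCCCNC(=O)c1ccccc1)NCCCOc1cccc(CN2CCCCC2)c1` gives 6.58 in this assay and stands lowest of the three numbers; compound 2 is its nearest neighbour and compound 1 its furthest, both differences lying beyond the scatter. Within the data shown here, the only single-site step among the measured compounds is a number 1.06 log units lower from compound 1 to compound 3 (beyond the scatter), a large loss.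

Compound 4 `N#CN/C(=N\CCNC(=O)CCCc1ccccc1)NCCCOc1cccc(CN2CCCCC2)c1` is not yet measured. It differs from compound 3 by ((3-phenylpropyl)carbonyl)amino in place of 3-benzamidopropyl on a saturated chain carbon, two bonds along the chain from a double-bonded nitrogen; the two are made of the same atoms, joined differently, so that a carbonyl-bearing amino group again sits on the saturated chain carbon two bonds along from the double-bonded nitrogen, the place at which compound 1 carries its benzoyloxy.

Among the measured compounds shown here, only the step from compound 1 to compound 3 bears on this change, and only loosely, since compound 4 carries an amide rather than the ester of compound 1 and the phenyl ring is held on a three-carbon chain beyond the carbonyl. Because compound 1 shows 7.64 with its carbonyl group at that place, compound 4 is expected to regain part of the ground lost in a number 1.06 log units lower from compound 1 to compound 3 (beyond the scatter), an upward step of a number 0.62 log units higher from compound 3 to compound 4 (beyond the scatter) being estimated, beyond the scatter but short of compound 1. Compound 4 is therefore estimated at 7.2, with a range from 6.6 to 7.8.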

Compound 4, negative logarithm of the antagonist equilibrium constant: 6.45
Compound 4: middle estimate off by 0.75 log units, on the high side; measured number below the stated range.
By their numbers in this assay, from the lowest: compounds 4 and 3 (each within the scatter of the next); then compounds 2 and 1 (each within the scatter of the next).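

In this assay the step is a number 0.13 log units lower from compound 3 to compound 4 (within the scatter) and so the two arrangements of the same atoms cannot be told apart: placing the amide as ((3-phenylpropyl)carbonyl)amino on the saturated chain carbon, two bonds along the chain from a double-bonded nitrogen, gives no separation from 3-benzamidopropyl at that place. A carbonyl-bearing group at that place does not by itself carry the number of compound 1, since the change from benzoyloxy to ((3-phenylpropyl)carbonyl)amino is a number 1.19 log units lower from compound 1 to compound 4 (beyond the scatter) and is large, while the change from 4-azido-2-nitrophenyl to (3-phenylpropyl)carbonyl on an amine nitrogen is a number 0.94 log units lower from compound 2 to compound 4 (beyond the scatter) and is modest. Nothing shown gives a reason for any of these steps.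

The compounds shown do not separate the effect of the ester from that of the chain beyond the carbonyl, a question that a plain benzamido group at the same place, with the phenyl ring directly on the amide carbonyl, would address. Also open is how a benzylamine or a carboxylic acid at that place would read out, as no group without a carbonyl or an aryl amine is among the compounds shown.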